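The source may report more compounds than this note shows. Statements on the series, on what has been measured and on what is new or still open speak of the compounds shown alone.

Measured so far in a functional assay, with a stated time of 20 min, tested at 50 uM; on this read-out higher numbers stand for a stronger effect at the one concentration tested and lower numbers for a weaker effect:
- compound 1 `COc1cc(/C=C/C(=O)C2=C(/C=C/c3ccc(O)c(OC)c3)NC(=O)NC2c2ccc(C)cc2)ccc1O`: 52.2%
- compound 2 `COc1cc(/C=C/C(=O)C2=C(/C=C/c3ccc(O)c(OC)c3)NC(=O)NC2c2ccccc2O)ccc1O`: 88%
- compound 3 `COc1cc(/C=C/C(=O)C2=C(/C=C/c3ccc(O)c(OC)c3)NC(=O)NC2c2ccc(O)cc2)ccc1O`: 86.2%

Compound 3 stands second highest of the three numbers in this assay. Its nearest neighbour is compound 2, the step being a number 1.8 percentage points lower from compound 2 to compound 3 (within the scatter) and so within the scatter, so no order between compound 2 and compound 3 can be read. Its furthest neighbour is compound 1, with a number 34 percentage points higher from compound 1 to compound 3 (beyond the scatter), a large step.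

The next compound is compound 4 `COc1cc(/C=C/C(=O)C2=C(/C=C/c3ccc(O)c(OC)c3)NC(=O)NC2c2c(Cl)cccc2Cl)ccc1O`, which differs from compound 3 in one place: 2,6-dichlorophenyl in place of 4-hydroxyphenyl on a saturated ring carbon.

Among the compounds with values here, two measured steps bear on this. a number 34 percentage points higher from compound 1 to compound 3 (beyond the scatter) and a number 35.8 percentage points higher from compound 1 to compound 2 (beyond the scatter) both show a large rise when a hydroxy-bearing phenyl stands in place of 4-methylphenyl, while a number 1.8 percentage points lower from compound 2 to compound 3 (within the scatter) shows that 2-hydroxyphenyl and 4-hydroxyphenyl give the same number within the scatter. Within the data shown here, compound 4 carries neither a hydroxy nor a methyl on that ring, and no measured compound holds chlorine there, so the expectation rests only on the observation that the one compound without a hydroxy, compound 1, sits low. For compound 4 a drop of about a number 28.2 percentage points lower from compound 3 to compound 4 (beyond the scatter) in this assay is therefore expected, beyond the scatter. Compound 4 is estimated at 58%, with a range from 38% to 78%.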

Compound 4, a percentage reported as activity, at one concentration (the size of the read-out at that concentration, not a potency): 44.2%
Beside the measured number, compound 4's estimate is 13.8 percentage points above it, within the range that was stated.
By their numbers in this assay, from the lowest: compounds 4 and 1 (each within the scatter of the next); then compounds 3 and 2 (each within the scatter of the next).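

In this assay, 2,6-dichlorophenyl on the saturated ring carbon sits well under both hydroxyphenyl groups, with a number 42 percentage points lower from compound 3 to compound 4 (beyond the scatter) and a number 43.8 percentage points lower from compound 2 to compound 4 (beyond the scatter). Against the 4-methylphenyl group no order can be read, with a number 8 percentage points lower from compound 1 to compound 4 (within the scatter), so across these four compounds the two without a hydroxy sit low, the two with one sit high, and none goes against this. No supporting data bear on the reason for this split.

As far as these compounds go, compound 4 changes the substituent and its ring places together, so it remains open how a single chlorine, as in 4-chlorophenyl, would read. Also open, from the compounds shown here alone, is whether the high level needs the hydroxy itself or would hold with an amine or a carboxylic acid on this phenyl ring.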